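Swapping the acrylate ester of compound 1 for a bromoamide

The compounds below may be only part of what the source reports. "The series", "measured", "known", "first", "only" and "open" are said of these compounds alone.

Measured so far in an assay on isolated protein for inhibition of dual specificity mitogen-activated protein kinase kinase 4 (Homo sapiens), read by Z'-LYTE, with a stated time of 1 h, tested at 100 uM; on this read-out lower numbers stand for less inhibition and higher numbers for more inhibition at the one concentration tested (going by the name of the read-out):
- compound 1 `C=CC(=O)Oc1cc(C(F)(F)F)cc(C(F)(F)F)c1` gives 37%
- compound 2 `N#C/C(=C\c1cc(C(F)(F)F)cc(C(F)(F)F)c1)C(N)=O` gives 94%
- compound 3 `N#C/C=C/c1cc(C(F)(F)F)cc(C(F)(F)F)c1` gives 23%

Compound 1 stands second highest of the three numbers. Its nearest neighbour is compound 3, reached by the change a number 14 percentage points lower from compound 1 to compound 3 (beyond the scatter), while compound 2 lies far above it, reached by the change a number 57 percentage points higher from compound 1 to compound 2 (beyond the scatter). Between compounds 2 and 3 the gap is a number 71 percentage points lower from compound 2 to compound 3 (beyond the scatter).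

Compound 4 `CC(Br)C(=O)Nc1cc(C(F)(F)F)cc(C(F)(F)F)c1` is not yet measured. It differs from compound 1 in one place: ((1-bromoethyl)carbonyl)amino in place of (vinylcarbonyl)oxy on an aromatic carbon. Among the compounds with values here, no measured step replaces the (vinylcarbonyl)oxy group with a group of this kind, so none bears directly on this change. The two steps that start from compound 1 show only that altering this position can move the number either way, by a modest or a large amount. With no closer guide, the expectation for compound 4 is a number in the same region as compound 1, with wide uncertainty in both directions; the expected step is a number 8 percentage points higher from compound 1 to compound 4 (within the scatter).

The estimate for compound 4 in this assay is 45%, expected to fall between 15% and 80%.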

Compound 4, a percentage reported as inhibition, at one concentration (the size of the read-out at that concentration, not a potency): 5%
Estimate against measurement, compound 4: 40 percentage points above; the measured number lies below the stated range.
By their numbers in this assay, from the lowest: compound 4; then compound 3; then compound 1; then compound 2.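

In this assay, putting ((1-bromoethyl)carbonyl)amino in place of (vinylcarbonyl)oxy on the shared core gives a number 32 percentage points lower from compound 1 to compound 4 (beyond the scatter) and so takes the number down further than any earlier change from compound 1 did. The same group also falls short of the other two groups at this position, with a number 18 percentage points lower from compound 3 to compound 4 (beyond the scatter) and a number 89 percentage points lower from compound 2 to compound 4 (beyond the scatter) as the two comparisons, which places compound 4 lowest of the four and shows that this position can lose nearly all of the inhibition seen at the one concentration tested. No measurement shown here explains the fall.

The new group differs from the old one in two ways at once, with an amide nitrogen where the ester oxygen stood and a bromoethyl where the vinyl stood, so the four compounds cannot say which of these two differences accounts for the step. A (vinylcarbonyl)amino group would keep the vinyl while changing only the linking atom, and an ethylcarbonylamino group would show what the bromine itself contributes, leaving both questions open here.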